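Amine exchange on compound 3: expectation for compound 4

The source may report more compounds than this note shows. Statements on the series, on what has been measured and on what is new or still open speak of the compounds shown alone.

In an ADME assay on MT4 cells (Homo sapiens) for cytotoxicity, read by MTT assay, with a stated time of 4 days (a lower number here means that less compound is tolerated, a higher number that more compound is tolerated), compound 1 (`CC(C)N(C)c1nc(Cc2c(F)cccc2F)cc(=O)[nH]1`) gives 85000 nM and compound 3 (`Cc1c(Cc2c(F)cccc2F)nc(N(C)C(C)C)[nH]c1=O`) gives 79000 nM, so compound 3 stands within the scatter of compound 1. Compound 2 (`O=c1cc(Cc2c(F)cccc2F)nc(N2CCCCC2)[nH]1`) gives > 82000 nM, which is a limit and not a number.

Compound 4 (`Cc1c(Cc2c(F)cccc2F)nc(N2CCCCC2C)[nH]c1=O`) has 2-methylpiperidin-1-yl in place of isopropyl(methyl)amino on an aromatic carbon. Two measured changes bear on this. The closest amine exchange is a step that the limit leaves unreadable from compound 1 to compound 2. The methyl change is a 1.1-fold lower number from compound 1 to compound 3 (0.03 log units; within the scatter). With no readable step behind it, no shift beyond the scatter is expected in this assay: the estimated change is a 1.1-fold lower number from compound 3 to compound 4 (0.05 log units; within the scatter). Compound 4 is estimated at 70000 nM, with an expected range of 30000 nM to 130000 nM.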

Compound 4, half-maximal cytotoxic concentration: 75000 nM
Beside the measured number, compound 4's estimate is 1.1-fold (0.03 log units) below it; the measured number falls inside the stated range.
By their numbers in this assay, from the lowest: compounds 4, 3 and 1 (each within the scatter of the next).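

In this assay, 2-methylpiperidin-1-yl in place of isopropyl(methyl)amino, on the aromatic carbon between two ring nitrogen atoms, gives a 1.1-fold lower number from compound 3 to compound 4 (0.02 log units; within the scatter). Among these compounds, this is the first readable amine exchange at this position, and it shows that a six-membered non-aromatic ring can replace the open-chain amine here without a shift beyond the scatter. The earlier exchange cannot be read because compound 2 stands at a limit: the limit of > 82000 nM in this assay, at which 1 of the 4 values shown sits.

Open, from the compounds shown here alone, is whether morpholin-4-yl or a carboxylic acid on the ring at this place would move the number beyond the scatter. Going by these compounds, the effect of the 2-methyl group itself also stays open, since no value here isolates it.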